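The compounds below may be only part of what the source reports. "The series", "measured", "known", "first", "only" and "open" are said of these compounds alone.

The shared core carries a butylamino group and an amino group on a pyrimidine fused to a saturated ring whose nitrogen bears a substituent. Compound 1 `CCCCNc1nc(N)nc2c1CCN(Cc1ccccc1)C2` has a benzyl group there and in an assay on HEK293 cells for agonist activity at Toll-like receptor 8 (Homo sapiens), read by a luciferase reporter, with a stated time of 6 h (on this read-out higher numbers stand for an effect only at larger amounts of compound and lower numbers for an effect already at smaller amounts), compound 1 gives 0.4 uM. Compound 2 `CCCCNc1nc(N)nc2c1CN(Cc1ccccc1Cl)CC2` carries a 2-chlorobenzyl group on a ring arranged differently, and in this assay compound 2 gives 0.05 uM, the second highest of the three numbers; compound 1 gives a higher number than compound 2, beyond the scatter. Compound 3 `CCCCNc1nc(N)nc2c1CN(Cc1cccc(OC)c1Cl)CC2` adds a methoxy group and in this assay compound 3 gives 0.04 uM; the step of a 1.3-fold lower number from compound 2 to compound 3 (0.10 log units; within the scatter) stays within the scatter.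

Compound 4 `CCCCNc1nc(N)nc2c1CN(C(=O)c1csc(N)n1)CC2` differs from compound 2 as follows: (2-amino-1,3-thiazol-4-yl)carbonyl in place of 2-chlorobenzyl on an amine nitrogen in a ring. Going by the values given here, no measured step exchanges the whole group on this ring nitrogen, so the only change with a number, the methoxy step, does not bear on it. In this assay compound 4 is expected to give 1 uM, within 0.15 uM to 8 uM; the expected step is a 20-fold higher number from compound 2 to compound 4 (1.30 log units; beyond the scatter), with a real chance that only a limit is reported.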

Compound 4, minimum effective concentration: 6.9 uM
Estimate against measurement, compound 4: 6.9-fold (0.84 log units) below; the range from low to high includes it.
By their numbers in this assay, from the lowest: compounds 3 and 2 (each within the scatter of the next); then compound 1; then compound 4.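

Exchanging the whole group on this amine nitrogen in a ring has a far larger effect in this assay than the earlier change on the aromatic ring: (2-amino-1,3-thiazol-4-yl)carbonyl in place of 2-chlorobenzyl gives a 140-fold higher number from compound 2 to compound 4 (2.14 log units; beyond the scatter), whereas adding a methoxy group gave only a 1.3-fold lower number from compound 2 to compound 3 (0.10 log units; within the scatter). Both groups count 8 heavy atoms, so this large step comes with no change in that count, only in what those atoms are and how they are arranged. Nothing measured here explains the step.

The exchange alters the carbonyl and the aromatic ring together, so the compounds shown do not tell which of the two carries the step. A 2-chlorobenzoyl group or a (2-amino-1,3-thiazol-4-yl)methyl group on the same nitrogen would separate them.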